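The compounds below may be only part of what the source reports. "The series", "measured", "known", "first", "only" and "open" are said of these compounds alone.

Compound 1 `C=C1CCC(c2csc(/C=C(\C)C(N)=O)c2)CC1`: 5010 nM in a functional assay on HeLa cells (Homo sapiens) for cytotoxicity, read by CCK-8 assay, with a stated time of 24 h; on this read-out lower numbers stand for stronger inhibition and higher numbers for weaker inhibition
Compound 2 `C/C(=C\c1cc(-c2ccc(F)cc2)cs1)C(N)=O`: 20800 nM

Among the compounds with values here, of the two numbers measured so far, compound 2 gives the higher one in this assay, and its nearest neighbour, compound 1, sits lower by a gap that lies beyond the scatter. Compound 3 `C/C(=C\c1cc(-c2ccc(Cl)cc2)cs1)C(N)=O` carries chloro in place of fluoro on an aromatic carbon. Within the data shown here, no measured pair shows what this change does on its own, so only a small step is expected, if any, leaning toward a somewhat lower number. On that basis compound 3 is expected to give about 15000 nM, between 5000 nM and 45000 nM, a step of a 1.4-fold lower number from compound 2 to compound 3 (0.14 log units; within the scatter) that stays within the scatter.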

Compound 3, half-maximal inhibitory concentration: > 50000 nM
Compound 3: only a limit was reported; the forecaster's own chance of this, stated with the estimate: 10%; middle value at least 3.3-fold (0.52 log units) from the limit.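

In this assay compound 3 gives > 50000 nM, which is a limit and not a number. It shows that this position on the six-membered aromatic ring does not tolerate every halogen equally: chloro in place of fluoro brings an at least 2.4-fold higher number from compound 2 to compound 3 (0.38 log units; beyond the scatter), a change that goes toward weaker inhibition. That step is only a minimum, because it rests on a limit: the limit of > 50000 nM in this assay, at which 1 of the 3 values shown sits.

The compounds shown leave open what a bromo, a methyl or an amine would do on this same aromatic carbon. They also leave open whether any group there could give a lower number than fluoro.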